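A Phthalimide-Bearing Triazole Series With No Detected Cytotoxicity

A few compounds are considered here, and "the series" means these few. Any claim that something is new, unique, unknown or untested is made for them only; others in the source may bear on it.

The compounds share a core in which a triazole carries a phthalimide-type nitrogen substituent, a sulfur-linked chain and a short alkyl chain. Compound 2 is `CSc1nnc(C)n1N1C(=O)c2ccccc2C1=O`. Compound 1 is `CCOC(=O)CSc1nnc(C)n1N1C(=O)c2ccccc2C1=O`, and it differs from compound 2 by ethoxycarbonyl in place of hydrogen on a saturated chain carbon bound to a sulfur. Compound 3 is `CCc1nnc(SC)n1N1C(=O)c2ccccc2C1=O`, differing from compound 2 by methyl in place of hydrogen on a saturated chain carbon bound to an aromatic carbon. The unmeasured compound 4 is `CCOC(=O)CSc1nnc(CC)n1N1C(=O)c2ccccc2C1=O`, and it differs from compound 3 by ethoxycarbonyl in place of hydrogen on a saturated chain carbon bound to a sulfur, the same change as that from compound 2 to compound 1.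

In a functional assay on A549 cells (Homo sapiens) for cytotoxicity, read by MTT assay, with a stated time of 48 h (on this read-out higher numbers stand for weaker inhibition and lower numbers for stronger inhibition), compound 2 gives > 200000 nM, which is a limit of the assay rather than a number. In this assay compound 1 likewise gives > 200000 nM, again a limit. Compound 3 in this assay gives > 200000 nM, also a limit. The step that the two limits leave unreadable from compound 2 to compound 1 and the step that the two limits leave unreadable from compound 2 to compound 3 therefore cannot be sized, because of the limit of > 200000 nM in this assay, at which 3 of the 3 values shown sit.

Compound 4 combines the two changes that separately left compound 1 and compound 3 at the limit. Since compound 3 gives > 200000 nM and compound 1 gives > 200000 nM, compound 4 is expected to sit at or beyond that limit as well. The expected step is a step that the limit leaves unreadable from compound 3 to compound 4, set beside the measured step that the two limits leave unreadable from compound 2 to compound 1. For compound 4 the estimate in this assay is 300000 nM, within a range from 150000 nM to 1000000 nM.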

Compound 4, half-maximal inhibitory concentration: > 200000 nM
Compound 4 gave a limit, no number; the forecaster's own chance of this, stated with the estimate: 85%; the middle value does not contradict the limit.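

In this assay compound 4 gives > 200000 nM, which is a limit and not a number. No new step can be read for compound 4, whether set against compound 3 or compound 1, because every value stands at the same limit: the limit of > 200000 nM in this assay, at which 4 of the 4 values shown sit.

The compounds shown leave open how large either change is in this assay, and whether any compound of this series gives a measurable value there.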